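The source may hold more compounds than are shown below. What is called first, only, known or untested is meant among the compounds shown, and "the series" means these compounds.

Among the measured compounds shown here, in a functional assay on HepG2 cells (Homo sapiens) for antiproliferative activity, read by MTT assay, with a stated time of 24 h (on this read-out lower numbers stand for stronger inhibition and higher numbers for weaker inhibition), compound 2 `Clc1ccc(C2=NN(c3ccc(-c4ccccc4)nn3)C(c3ccccc3)C2)cc1` gives 8750 nM, the lower of the two numbers measured so far. Compound 1 `COc1cc(C2CC(c3ccccc3)=NN2c2ccc(-c3ccccc3)nn2)cc(OC)c1OC` gives 100000 nM in this assay, a higher number by a gap well beyond the usual scatter, so compound 2 inhibits cell growth more strongly than compound 1.

Compound 3 `COc1ccc(C2CC(c3ccc(Cl)cc3)=NN2c2ccc(-c3ccccc3)nn2)c(OC)c1` has not yet been measured. It differs from compound 2 in one place: 2,4-dimethoxyphenyl in place of phenyl on a saturated ring carbon. For the measured compounds named here, no pair of measured compounds differs in exactly this way, so the size of this step cannot be read off directly. What the data do show is that compound 1, which also carries a methoxy-bearing phenyl on a saturated ring carbon of the shared core, gives 100000 nM, whereas compound 2 with a plain phenyl there gives 8750 nM. On that basis the step from compound 2 to compound 3 is expected to go toward weaker inhibition, a 3.4-fold higher number from compound 2 to compound 3 (0.54 log units; beyond the scatter), clearly beyond the scatter. Compound 3 is therefore estimated at 30000 nM in this assay, with a likely range from 9000 nM to 100000 nM.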

Compound 3, half-maximal inhibitory concentration: > 100000 nM
Compound 3: a limit, no number; the forecaster's own chance of this, stated with the estimate: 25%; middle value at least 3.3-fold (0.52 log units) away from the limit.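

Among the compounds shown here, replacing phenyl with 2,4-dimethoxyphenyl on the saturated ring carbon is the first change here that can be read in a single place, and it gives an at least 11-fold higher number from compound 2 to compound 3 (1.05 log units; beyond the scatter). So, with the 4-chlorophenyl group held fixed, inhibition at this position depends strongly on which aromatic group sits there, and this one change is enough to take away most of the activity seen with plain phenyl. In this assay compound 3 gives > 100000 nM, which is a limit of the assay and not a number, so the step shows only a minimum size and its full size cannot be read: the limit of > 100000 nM in this assay, at which 1 of the 3 values shown sits.

The compounds shown leave open which part of the 2,4-dimethoxyphenyl group matters, since both methoxy groups enter together and a phenyl carrying a single methoxy group would be needed to separate them. They also leave open how other groups on this phenyl ring, such as a hydroxyl, an amine or a carboxylic acid, would compare with plain phenyl.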